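The source may report more compounds than this note shows. Statements on the series, on what has been measured and on what is new or still open speak of the compounds shown alone.

Measured so far in this assay, an ADME assay on Vero cells (Chlorocebus sabaeus) for cytotoxicity, read by resazurin assay, with a stated time of 2 days; on this read-out higher numbers stand for lower toxicity in this test and lower numbers for higher toxicity in this test:
compound 1 `CC(=O)OC[C@H]1O[C@@H](CC(=O)/C=C/c2cccc(NS(=O)(=O)c3ccc(C)cc3)c2)[C@H](OC(C)=O)[C@@H](OC(C)=O)[C@@H]1OC(C)=O` gives 584000 nM;
compound 2 `CC(=O)OC[C@H]1O[C@@H](CC(=O)/C=C/c2ccc(NC(=O)Nc3ccccc3)cc2)[C@H](OC(C)=O)[C@@H](OC(C)=O)[C@@H]1OC(C)=O` gives 820000 nM;
compound 3 `CC(=O)OC[C@H]1O[C@@H](CC(=O)/C=C/c2cccc(NC(=S)Nc3ccccc3)c2)[C@H](OC(C)=O)[C@@H](OC(C)=O)[C@@H]1OC(C)=O` gives 337000 nM.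

Compound 1 stands second highest of the three numbers in this assay. Compound 2 sits closest to it, and the gap between the two lies within the scatter of repeated runs. Going by the values given here, the one measured step that starts from compound 1, a 1.7-fold lower number from compound 1 to compound 3 (0.24 log units; within the scatter), also lies within the scatter, and it concerns a swap of the group on the aromatic nitrogen rather than anything on the sugar part of the shared core.

Compound 4 `CC(=O)OC[C@H]1O[C@@H](CC(=O)/C=C/c2cccc(NS(=O)(=O)c3ccc(C)cc3)c2)[C@@H](OC(C)=O)[C@@H](OC(C)=O)[C@@H]1OC(C)=O` is the next compound for this assay. Its relation to compound 1 is narrow: the two compounds have the same atoms and bonds and differ only in configuration as drawn: 1 of 6 stereo elements differ; a stereocentre at a saturated ring carbon is drawn S in compound 1 and R in compound 4. Among the compounds with values here, no measured step covers a change of configuration, so nothing among the three values bears directly on this move; the step from compound 1 to compound 3 only shows that a far larger change at the aromatic nitrogen left this assay inside the scatter. With no signal pointing in either direction, the expectation for compound 4 is no step beyond the scatter, a 1.0-fold lower number from compound 1 to compound 4 (0.00 log units; within the scatter). Compound 4 is therefore estimated at 580000 nM in this assay, with a range from 290000 nM to 1160000 nM.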

Compound 4, half-maximal cytotoxic concentration: 123000 nM
Beside the measured number, compound 4's estimate is 4.7-fold (0.67 log units) above it, outside the stated range (below it).
By their numbers in this assay, from the lowest: compound 4; then compounds 3, 1 and 2 (each within the scatter of the next, the first and the last beyond it).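

In this assay, going by these compounds alone, the configuration at a saturated ring carbon carries a step of its own, a 4.7-fold lower number from compound 1 to compound 4 (0.68 log units; beyond the scatter), whereas the one earlier step, a 1.7-fold lower number from compound 1 to compound 3 (0.24 log units; within the scatter), stayed within the scatter despite a much larger change in the group on the aromatic nitrogen. For this pair, then, the lower number, which stands for higher toxicity in this test, comes from the shared core and not from the group on the aromatic nitrogen. The step can be assigned to the single centre drawn S in one compound and R in the other because nothing else separates the two structures: the fact that compounds 1 and 4 differ only in the configuration as drawn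

Still open, going by these compounds, is whether the R centre lowers the number to a similar extent when the aromatic nitrogen carries another group, such as the phenyl thiourea of compound 3 or the phenyl urea of compound 2, and whether changing any of the other stereocentres has a comparable effect. Also open, on these data alone, is how the number responds when the acetate groups on the sugar part are replaced by free hydroxyl groups or methyl ethers, in either configuration at this carbon.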